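This account rests on a few compounds, and the source may have more. Where it says the series, first, only, none or still open, it means among the compounds named here.

Compound 1 `COc1ccc(Cl)cc1S(=O)(=O)Nc1cncc(-c2cccnc2)c1` and compound 2 `COc1ccc(OC)c(S(=O)(=O)Nc2cncc(-c3ccncc3)c2)c1` carry the shared core with different substitution on both outer rings. In an assay on isolated protein for inhibition of alkaline phosphatase, tissue-nonspecific isozyme (Homo sapiens) (on this read-out higher numbers stand for weaker inhibition and lower numbers for stronger inhibition), compound 1 gives 73 nM. In this assay compound 2 gives 73 nM, level with compound 1 at the digits shown; the two values lie within the usual scatter of each other, so no order between them is claimed. Compound 3 `COc1ccc(Cl)cc1S(=O)(=O)Nc1cncc(-c2ccncc2)c1` differs from compound 2 by chloro in place of methoxy on an aromatic carbon. Among the compounds with values here, no measured pair shows this exchange, so nothing beyond the scatter is expected in either direction: a 1.0-fold lower number from compound 2 to compound 3 (0.02 log units; within the scatter). In this assay compound 3 is estimated at 70 nM, with a range from 30 nM to 160 nM.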

Compound 3, half-maximal inhibitory concentration: 73 nM
Compound 3: the middle estimate sits 1.0-fold (0.02 log units) below what was measured, within the range that was stated.
By their numbers in this assay, from the lowest: compounds 1, 2 and 3 (each within the scatter of the next).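

In this assay chloro in place of methoxy, on the aromatic carbon para to a methoxy group, gives no change at the digits printed from compound 2 to compound 3 (within the scatter) and so separates this exchange from the change at the other ring. Pyridin-4-yl in place of pyridin-3-yl gives no change at the digits printed from compound 1 to compound 3 (within the scatter) in the same read-out, so neither single exchange moves the number beyond the scatter. Still open, on these data alone, is whether an amine or a carboxylic acid at the chloro position, or a pyridin-2-yl group at the pyridine position, would shift the value. Nothing available bears on why these two exchanges leave the number in place.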